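Trifluoromethyl in Place of Methyl on Two Related Cores

The source may report more compounds than this note shows. Statements on the series, on what has been measured and on what is new or still open speak of the compounds shown alone.

Compound 1 `Cc1ccc(-c2cc(/C=C/c3ccc(C(=O)NO)cc3)ccn2)cc1` was tested in a functional assay on HCT-116 cells (Homo sapiens) for antiproliferative activity, read by CellTiter-Glo, with a stated time of 72 h (on this read-out higher numbers stand for weaker inhibition and lower numbers for stronger inhibition), where compound 1 gives 2390 nM. Compound 2 `O=C(NO)c1ccc(/C=C/c2ccnc(-c3ccc(C(F)(F)F)cc3)c2)cc1` carries trifluoromethyl in place of methyl on an aromatic carbon. In this assay compound 2 reaches only a limit of the assay, > 10000 nM. The measured step is an at least 4.1-fold higher number from compound 1 to compound 2 (0.62 log units; beyond the scatter). Compound 3 `Cc1ccc(-c2cncc(/C=C/c3ccc(C(=O)NO)cc3)c2)cc1` has the same atoms as compound 1 joined differently; the difference between the two cores is not broken down here. In this assay compound 3 also sits at a limit of the assay, > 10000 nM. Compound 4 `O=C(NO)c1ccc(/C=C/c2cncc(-c3ccc(C(F)(F)F)cc3)c2)cc1` carries trifluoromethyl in place of methyl on an aromatic carbon, the same change as before at the same place. Weak inhibition is expected for compound 4, since the limit of > 10000 nM in this assay, at which 2 of the 3 values shown sit, already holds two of the three values and the step of an at least 4.1-fold higher number from compound 1 to compound 2 (0.62 log units; beyond the scatter) went towards weaker inhibition. The expected step that the limit leaves unreadable from compound 3 to compound 4 is estimated to leave compound 4 at 15000 nM.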

Compound 4, half-maximal inhibitory concentration: > 10000 nM
Compound 4 gave a limit, no number; the forecaster's own chance of this, stated with the estimate: 85%; the middle value lies beyond the limit too.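

Among the compounds shown here, compound 3 and compound 4 both sit at a limit in this assay, and no step between them can be read. The compounds shown leave open whether trifluoromethyl in place of methyl weakens inhibition on the core of compound 3 as well.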